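The source may hold more compounds than are shown below. What is called first, only, known or untested is meant among the compounds shown, and "the series" means these compounds.

Compound 1, `CCCn1c(=O)[nH]c2nc(-c3ccc(S(=O)(=O)N4CCN(c5ccc(Cl)cc5F)CC4)cc3)[nH]c2c1=O`: in an assay on CHO cells for displacement of a labelled ligand from adenosine receptor A1 (Homo sapiens), read by scintillation counting, with a stated time of 90 min, in the presence of a further agent that is not named here (a lower number here means a stronger inhibitor, a higher number a weaker inhibitor), compound 1 gives > 1000 nM, which is a limit of the assay and not a number.
Compound 2, `CCCn1c(=O)[nH]c2nc(-c3ccc(S(=O)(=O)N4CCN(c5ccc(Br)cc5)CC4)cc3)[nH]c2c1=O`: in this assay compound 2 gives > 1000 nM, again a limit of the assay.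
Compound 3, `CCCn1c(=O)[nH]c2nc(-c3ccc(S(=O)(=O)N4CCN(c5ccccc5C)CC4)cc3)[nH]c2c1=O`: in this assay compound 3 gives 419 nM.

For the measured compounds named here, compound 3 therefore stands as the only compound of the three with an actual number; the other two sit at the limit of > 1000 nM in this assay, at which 2 of the 3 values shown sit. Two measured steps lead to it, an at least 2.3-fold lower number from compound 1 to compound 3 (0.37 log units; beyond the scatter) and an at least 2.3-fold lower number from compound 2 to compound 3 (0.37 log units; beyond the scatter), both beyond the scatter, while the step that the two limits leave unreadable from compound 1 to compound 2 remains unreadable between two limits.

Compound 4, `CCCn1c(=O)[nH]c2nc(-c3ccc(S(=O)(=O)N4CCN(C)CC4)cc3)[nH]c2c1=O`, differs from compound 3 by methyl in place of 2-methylphenyl on an amine nitrogen in a ring. The measured steps all concern the exchange of one aromatic ring for another on that ring nitrogen, and they show that this position moves the number by at least a modest amount. None of them removes the aromatic ring altogether, so the direction of the present change cannot be read directly from them. Given that two of the three aryl variants already fall at the limit, a weaker number is expected for compound 4, as a 3.6-fold higher number from compound 3 to compound 4 (0.55 log units; beyond the scatter). Compound 4 is estimated at 1500 nM, between 300 nM and 8000 nM, with a real chance that only a limit is reported.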

Compound 4, inhibition constant: 334 nM
Compound 4: the middle estimate sits 4.5-fold (0.65 log units) above what was measured; the measured number falls inside the stated range.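

In this assay, the aromatic ring on the amine nitrogen turns out not to be needed for a measurable number: methyl in place of 2-methylphenyl gives a 1.3-fold lower number from compound 3 to compound 4 (0.10 log units; within the scatter), so the two groups cannot be told apart here. Set against the other two aryl groups, the same methyl gives an at least 2.9-fold lower number from compound 2 to compound 4 (0.47 log units; beyond the scatter) and an at least 2.9-fold lower number from compound 1 to compound 4 (0.47 log units; beyond the scatter), so the loss seen earlier belongs to 4-bromophenyl and 4-chloro-2-fluorophenyl in particular, not to every change at this position. The presence of an aromatic ring on that nitrogen therefore does not set the number by itself, as compound 3 carries one and stands level with compound 4, while compound 1 and compound 2 carry one and remain at a limit of the assay: the limit of > 1000 nM in this assay, at which 2 of the 4 values shown sit.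

The compounds shown leave open whether a plain hydrogen on that ring nitrogen, a longer chain such as propyl, or a benzyl group would hold the number, and whether unsubstituted phenyl would sit with compound 3 or with compound 1 and compound 2. They also leave open which feature separates 2-methylphenyl from the two halogen-bearing aryl groups.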